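Amide in Place of Acid: Expected Cytotoxicity Stays Low

The source may hold more compounds than are shown below. What is called first, only, known or untested is meant among the compounds shown, and "the series" means these compounds.

Compound 1 `O=c1n(Cc2cn3ccc(Cl)cc3n2)c2cnccc2n1C1CC1`: 22300 nM
Compound 2 `O=c1n(Cc2nc3cc(Cl)ccn3c2CO)c2cnccc2n1C1CC1`: > 100000 nM
Compound 3 `O=C(O)c1c(Cn2c(=O)n(C3CC3)c3ccncc32)nc2cc(Cl)ccn12`: > 100000 nM

Of the compounds shown here, three share one core and have been tested in an ADME assay on HEp-2 cells (Homo sapiens) for cytotoxicity, read by CCK-8 assay, with a stated time of 6 days; on this read-out higher numbers stand for lower toxicity in this test and lower numbers for higher toxicity in this test. Compound 1 gives 22300 nM. Compound 2 reaches only the limit of the assay, > 100000 nM. Compound 3 likewise sits at the limit of the assay, > 100000 nM, so only a lower bound is known for it, and the limit of > 100000 nM in this assay, at which 2 of the 3 values shown sit, shows that it shares this position with one other compound. The step of an at least 4.4-fold higher number from compound 1 to compound 3 (0.65 log units; beyond the scatter) and the step of an at least 4.4-fold higher number from compound 1 to compound 2 (0.65 log units; beyond the scatter) both run toward lower toxicity, while the step that the two limits leave unreadable from compound 2 to compound 3 cannot be sized.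

Compound 4 `O=C(NCCO)c1c(Cn2c(=O)n(C3CC3)c3ccncc32)nc2cc(Cl)ccn12` is not yet measured. Its difference from compound 3 is (2-hydroxyethyl)amino in place of hydroxy on a carbonyl carbon, so the carboxy becomes a (2-hydroxyethyl)carbamoyl. The two readable steps show that adding a polar group at this position moved the number to the limit; the present change keeps a hydroxy and adds an amide. Going by the values given here, no measured step reports on this exact exchange, so the expectation rests on compound 3 standing at the limit. Compound 4 is expected to give about 100000 nM, within 30000 nM to 300000 nM, so the expected step of a number no higher from compound 3 to compound 4 (the limit leaves the size open) is essentially none beyond the scatter.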

Compound 4, half-maximal cytotoxic concentration: > 100000 nM
Compound 4: no number, only a limit (the forecaster's own chance of this, stated with the estimate: 70%); the middle value sits exactly at the limit.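

Going by these compounds alone, the core of compound 1 has now taken a third kind of group on this aromatic carbon, and the one step that can be read is an at least 4.4-fold higher number from compound 1 to compound 4 (0.65 log units; beyond the scatter). That step runs the same way as the changes to hydroxymethyl and carboxy, so in this assay the larger (2-hydroxyethyl)carbamoyl, with its amide and its hydroxy, does not bring the number back inside the measurable range. The steps among compound 2, compound 3 and compound 4 cannot be read, since each of these compounds gives only a limit, so no order among them can be stated, and all three share one position: the limit of > 100000 nM in this assay, at which 3 of the 4 values shown sit.

From the compounds shown here alone, how far beyond the limit any of these three compounds lies remains unknown, so the exchange of hydroxy for (2-hydroxyethyl)amino on the carbonyl carbon has no size in this test. Also open, going by these compounds, is whether a plain primary amide, a methyl ester, an aminomethyl group or a longer chain on the amide nitrogen, such as 3-hydroxypropyl, would stay at the limit or give a measurable number.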